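Swapping an Amide for a Ring Ketone on the Core

The compounds below may be only part of what the source reports. "The series", "measured", "known", "first", "only" and "open" are said of these compounds alone.

In a functional assay on CHO cells for antagonist activity at C-X-C chemokine receptor type 3 (Homo sapiens), read by GTPgammaS binding, with a stated time of 30 min (a lower number here means a stronger inhibitor, a higher number a weaker inhibitor), two compounds have been measured:
compound 1 `O=CN1CCCC(c2ccccc2)(C2CCN(Cc3ccc(Br)cc3)CC2)C1` gives 150 nM
compound 2 `CCC(=O)N1CCCC(c2ccccc2)(C2CCN(Cc3ccc(Br)cc3)CC2)C1` gives 290 nM

Compound 2 holds the higher of the two numbers, yet the step of a 1.9-fold higher number from compound 1 to compound 2 (0.29 log units; within the scatter) lies within the scatter, so the two stand level. Compound 3 `O=C1CC1N1CCCC(c2ccccc2)(C2CCN(Cc3ccc(Br)cc3)CC2)C1` carries 2-oxocyclopropyl in place of propanoyl on an amine nitrogen in a ring. For the measured compounds named here, the only measured step changed the group on the carbonyl carbon without moving the number beyond the scatter; no measured step replaces the amide itself with a ring ketone, so nothing shows how that will read. Compound 3 is therefore expected near compound 2, estimated at 350 nM with a range of 100 nM to 1200 nM. That estimate means an expected step of a 1.2-fold higher number from compound 2 to compound 3 (0.08 log units; within the scatter), within the scatter.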

Compound 3, half-maximal inhibitory concentration: 180 nM
For compound 3 the middle estimate is 1.9-fold (0.29 log units) above the measured one; measured number inside the range.
By their numbers in this assay, from the lowest: compounds 1, 3 and 2 (each within the scatter of the next).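

Putting 2-oxocyclopropyl on the amine nitrogen in place of propanoyl gives a 1.6-fold lower number from compound 2 to compound 3 (0.21 log units; within the scatter) and putting it in place of formyl gives a 1.2-fold higher number from compound 1 to compound 3 (0.08 log units; within the scatter) in this assay at this position. Across these three compounds, the carbonyl can therefore leave the amide link and a three-membered ring can replace the open chain while the numbers stay level. Nothing on hand explains this result. On these data alone, whether an amine, a carboxylic acid or a longer chain on this nitrogen would also stay level remains open.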